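Shifting the aryl substituent on a triazole sulfonamide

The source may hold more compounds than are shown below. What is called first, only, known or untested is meant among the compounds shown, and "the series" means these compounds.

Measured compounds:
- compound 1 `Cc1ccc(-n2cc(-c3ccc(NS(=O)(=O)c4c[nH]c(=O)[nH]c4=O)cc3)nn2)cc1` gives 5560 nM
- compound 2 `O=c1[nH]cc(S(=O)(=O)Nc2ccc(-c3cn(-c4ccc(F)cc4)nn3)cc2)c(=O)[nH]1` gives 9720 nM

Both compounds were tested in a functional assay on A549 cells (Homo sapiens) for antiproliferative activity, read by MTT assay, with a stated time of 24 h; on this read-out higher numbers stand for weaker inhibition and lower numbers for stronger inhibition. Compound 2 has the highest number of the two; its nearest neighbour is compound 1, and the step of a 1.7-fold higher number from compound 1 to compound 2 (0.24 log units; within the scatter) lies within the scatter, so the two cannot be told apart on these numbers.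

Compound 3 `O=c1[nH]cc(S(=O)(=O)Nc2ccc(-c3cn(-c4cccc(Cl)c4)nn3)cc2)c(=O)[nH]1` is not yet measured. It differs from compound 2 in one place: 3-chlorophenyl in place of 4-fluorophenyl on an aromatic nitrogen. Going by the values given here, no measured step matches this change. Among the compounds with values here, the only step on record, from compound 1 to compound 2, swaps one small group on the same aromatic carbon and leaves the number essentially unchanged; compound 3 instead alters both the halogen and where it sits on that ring, so that step gives only a loose guide.

With nothing pointing in either direction, no move beyond the scatter is expected, and the estimated step is a 1.3-fold lower number from compound 2 to compound 3 (0.11 log units; within the scatter). Compound 3 is expected to give about 7500 nM in this assay, with a likely range from 2500 nM to 22000 nM.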

Compound 3, half-maximal inhibitory concentration: 2310 nM
For compound 3 the middle estimate is 3.2-fold (0.51 log units) above the measured one, and the stated range ends above it.
By their numbers in this assay, from the lowest: compound 3; then compounds 1 and 2 (each within the scatter of the next).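

In this assay, the aryl group on the aromatic nitrogen of the five-membered ring now proves able to shift the number beyond the scatter. Placing 3-chlorophenyl there gives a modest gain over 4-fluorophenyl (a 4.2-fold lower number from compound 2 to compound 3 (0.62 log units; beyond the scatter)) and over 4-methylphenyl (a 2.4-fold lower number from compound 1 to compound 3 (0.38 log units; beyond the scatter)), whereas the earlier swap between the two para-free labels of this series, fluoro for methyl, could not be told apart (a 1.7-fold higher number from compound 1 to compound 2 (0.24 log units; within the scatter)), so compound 3 is the strongest inhibitor of the three. Nothing on hand explains this gain.

As far as these compounds go, the step from compound 2 to compound 3 changes both the halogen and its place on the ring, so it stays open whether the chlorine or its place carries the effect; a 4-chlorophenyl or a 3-fluorophenyl group at the same position would pull these two apart. From the compounds shown here alone, how far the trend reaches is also open, since a quite different substituent on this ring, such as an amine or a carboxylic acid, could move the number either way.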